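This account rests on a few compounds, and the source may have more. Where it says the series, first, only, none or still open, it means among the compounds named here.

In a functional assay on Bel-7402 cells (Homo sapiens) for antiproliferative activity, read by MTT assay, with a stated time of 72 h (on this read-out higher numbers stand for weaker inhibition and lower numbers for stronger inhibition), compound 1 (`C=C1C(=O)O[C@H]2[C@H]1CC/C(COC(=O)Cn1cc(F)c(=O)n(Cc3ccccc3)c1=O)=C\CC[C@@]1(C)O[C@@H]21`) gives 3980 nM and compound 2 (`C=C1C(=O)O[C@H]2[C@H]1CC/C(COC(=O)Cn1cc(F)c(=O)n(Cc3ccc(F)cc3)c1=O)=C\CC[C@@]1(C)O[C@@H]21`) gives 2730 nM. Within the data shown here, these are the only two numbers so far, and they lie within the scatter of each other, so compound 2 stands level with compound 1 rather than clearly apart from it.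

Compound 3 (`C=C1C(=O)O[C@H]2[C@H]1CC/C(COC(=O)Cn1cc(F)c(=O)n(Cc3ccc(Cl)cc3)c1=O)=C\CC[C@@]1(C)O[C@@H]21`) departs from compound 2 at a single place, on an aromatic carbon of a six-membered aromatic ring of carbon only, para to a large group: chloro in place of fluoro on an aromatic carbon. In words, chloro takes the place of fluoro, turning the 4-fluorobenzyl into a 4-chlorobenzyl.

Among the measured compounds shown here, one measured step bears on this change, since it touches the same place, where fluoro replaced hydrogen: a 1.5-fold lower number from compound 1 to compound 2 (0.16 log units; within the scatter). For the measured compounds named here, no measured step yet has chloro entering. Going by the values given here, with compound 2 at 2730 nM and that one small step as the only guide, no shift beyond the scatter is expected in this assay, and no direction can be favoured. The expected result is a 1.1-fold lower number from compound 2 to compound 3 (0.04 log units; within the scatter). The estimate for compound 3 is 2500 nM, with an expected range from 1200 nM to 5200 nM.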

Compound 3, half-maximal inhibitory concentration: 2560 nM
The estimate for compound 3 lay 1.0-fold (0.01 log units) below the measured number, and the stated range covers the measured number.
By their numbers in this assay, from the lowest: compounds 3, 2 and 1 (each within the scatter of the next).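

Chloro now joins fluoro on this aromatic carbon, para to a large group, and in this assay the exchange of one halogen for the other leaves the result within the scatter, with a 1.1-fold lower number from compound 2 to compound 3 (0.03 log units; within the scatter). Set against hydrogen at this place, chloro also stays within the scatter, with a 1.6-fold lower number from compound 1 to compound 3 (0.19 log units; within the scatter), so hydrogen, fluoro and chloro all stand level here, whereas the earlier pair had tested only fluoro against hydrogen and could not show whether a second halogen would behave the same way. No measurement at hand explains why these three substituents stand level, and the compounds give no reason for it.

From the compounds shown here alone, what remains open is whether this position responds at all to a group of another kind, such as a methoxy, a nitrile, an amine or a carboxylic acid, since so far only hydrogen and two single-atom halogens have been compared there. Also open, going by these compounds, is whether a substituent elsewhere on the six-membered aromatic ring, or a longer chain in place of the benzyl, would move the number beyond the scatter.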